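This account rests on a few compounds, and the source may have more. Where it says the series, first, only, none or still open, it means among the compounds named here.

In a functional assay on HeLa cells (Homo sapiens) for cytotoxicity, read by ELISA, with a stated time of 4 days (a lower number here means a stronger inhibitor, a higher number a weaker inhibitor), compound 3 (`Clc1cccc(-c2cc(-c3ccc(Cl)o3)cc(-c3ccc(Cl)s3)n2)c1`) gives 25200 nM as its reading and compound 1 (`Cc1ccsc1-c1cc(-c2ccc(Cl)o2)cc(-c2ccc(Cl)cc2)n1`) gives 29300 nM as its reading. These two values lie within the scatter of each other, so neither can be ranked over the other. Compound 2 (`Cc1ccc(-c2cc(-c3ccc(Cl)o3)cc(-c3ccc(Cl)s3)n2)cc1`) is reported as > 50000 nM which is a limit and not a number.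

The next compound to consider is compound 4 (`Clc1ccc(-c2cc(-c3ccc(Cl)o3)cc(-c3ccc(Cl)s3)n2)cc1`). It has 4-chlorophenyl in place of 3-chlorophenyl on an aromatic carbon next to the ring nitrogen (4-chlorophenyl in place of 3-chlorophenyl on an aromatic carbon), so the two compounds have the same atoms, joined differently.

Within the data shown here, only one measured step changes this same place: (an at least 1.9-fold lower number from compound 2 to compound 3 (0.29 log units; that floor lies within the scatter)) where 3-chlorophenyl replaces 4-methylphenyl. That step starts from a limit and its floor stays within the scatter, so it offers no firm sign that changes here move the number. Compound 1 also carries 4-chlorophenyl, although it differs elsewhere, and its value of 29300 nM gives no hint of a large loss or gain.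

No shift beyond the scatter is therefore expected, and the expected change is (a 1.1-fold higher number from compound 3 to compound 4 (0.05 log units; within the scatter)) in size. For compound 4 the estimated value is 28000 nM with an expected range from 13000 nM to 50000 nM in this test.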

Compound 4, half-maximal inhibitory concentration: 25100 nM
The estimate for compound 4 lay 1.1-fold (0.05 log units) above the measured number; the measured number falls inside the stated range.
By their numbers in this assay, from the lowest: compounds 4, 3 and 1 (each within the scatter of the next). At a limit, above all of these: compound 2.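

Moving the chlorine on the phenyl ring, so that 4-chlorophenyl stands in place of 3-chlorophenyl, gives a 1.0-fold lower number from compound 3 to compound 4 (0.00 log units; within the scatter) in this assay, so this position does not tell the two arrangements of the same atoms apart. A change at a different place, 5-chlorothiophen-2-yl in place of 3-methylthiophen-2-yl, gives a 1.2-fold lower number from compound 1 to compound 4 (0.07 log units; within the scatter), so that swap of one thiophene group for another cannot be told from the scatter either. Chloro in place of methyl on an aromatic carbon gives an at least 1.9-fold lower number from compound 2 to compound 4 (0.29 log units; that floor lies within the scatter), which is only a floor, and this step has no firm size because its starting value is a limit and not a number: the limit of > 50000 nM in this assay, at which 1 of the 4 values shown sits.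

So far, every change with a readable size stays within the scatter, which leaves open whether any change at this position can move the number beyond it. A primary amine or a carboxylic acid on the phenyl ring, or a longer alkyl chain in place of the chloro, would test this, as would replacing the 5-chlorofuran-2-yl group with an amine-bearing group.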